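Working notes: from compound 1 to compound 3

This account rests on a few compounds, and the source may have more. Where it says the series, first, only, none or still open, it means among the compounds named here.

Measured so far in a physicochemical assay for solubility; a higher number here means a more soluble compound, a lower number a less soluble compound
compound 1 `CCCCCC(=O)n1c(=S)[nH]c2ccccc21` gives 170000 nM
compound 2 `CC(=O)n1c(=S)[nH]c2ccccc21` gives 460000 nM

Of these two numbers, compound 1 holds the lower (170000 nM) and compound 2 the higher. Going by the values given here, the only measured step (a 2.7-fold higher number from compound 1 to compound 2 (0.43 log units; beyond the scatter)) is modest but beyond the scatter, and it places hydrogen in place of butyl on a saturated chain carbon bound to a carbonyl carbon.

The next compound is compound 3 `O=C(CCc1ccccc1)n1c(=S)[nH]c2ccccc21`, still unmeasured. Its difference from compound 1 (phenyl in place of propyl on a saturated chain carbon, two bonds along the chain from a carbonyl carbon) is phenyl in place of propyl on a saturated chain carbon, two bonds along the chain from a carbonyl carbon.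

Among the compounds with values here, that single step is a weak guide, as no measured compound carries a ring at this place. Compound 2 (460000 nM) pairs the smaller group with the higher number, so a modest move to a lower number in this assay is expected, though none beyond the scatter remains possible. The estimated step is (a 1.8-fold lower number from compound 1 to compound 3 (0.25 log units; within the scatter)). For compound 3 the expected value is 95000 nM within an estimated range of 35000 nM to 220000 nM.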

Compound 3, solubility: 100000 nM
Compound 3: middle estimate off by 1.1-fold (0.02 log units), on the low side; the range from low to high includes it.
By their numbers in this assay, from the lowest: compounds 3 and 1 (each within the scatter of the next); then compound 2.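

In this assay, going by these compounds alone, the step (a 1.7-fold lower number from compound 1 to compound 3 (0.23 log units; within the scatter)) is the first reading of a ring at this place, on a saturated chain carbon, two bonds along the chain from a carbonyl carbon. The swap brings in phenyl, with one six-membered aromatic ring of carbon only and 6 heavy atoms against the 3 of propyl, yet compound 1 and compound 3 remain within the scatter of each other, so this change has no readable effect on the number. The other step in the series (a 2.7-fold higher number from compound 1 to compound 2 (0.43 log units; beyond the scatter)) is therefore still the only one beyond the scatter, and no available data bear on the reason for either result.

Open is whether an amine or a carboxylic acid at this same place would move the number beyond the scatter, as neither group appears in the compounds shown. Also open, from the compounds shown here alone, is whether a longer chain or a ring containing nitrogen would behave like propyl and phenyl here, and whether substituents on the phenyl ring of compound 3 would leave its number within the scatter of compound 1.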